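The source may hold more compounds than are shown below. What is called first, only, known or untested is meant among the compounds shown, and "the series" means these compounds.

Compound 3 `O=C(COc1cccc2ccccc12)N/N=C/c1ccc(Cl)cc1` gives 100 ug/mL in an ADME assay on HEL cells (Homo sapiens) for cytotoxicity (a higher number here means that more compound is tolerated, a lower number that less compound is tolerated), the highest of the two plain numbers, standing above compound 1 `O=C(COc1cccc2ccccc12)N/N=C/c1ccc(O)cc1`, which gives 20 ug/mL in this assay; the step of a 5.0-fold higher number from compound 1 to compound 3 (0.70 log units; beyond the scatter) lies beyond the scatter. Compound 2 `O=C(COc1cccc2ccccc12)N/N=C/c1ccccc1Br` gives only a limit of the assay, >= 20 ug/mL. One of the three values shown is such a limit (the limit of >= 20 ug/mL in this assay, at which 1 of the 3 values shown sits), so the steps of a number no lower from compound 1 to compound 2 (the limit leaves the size open) and a step that the limit leaves unreadable from compound 2 to compound 3 cannot be sized. Compound 4 `O=C(COc1cccc2ccccc12)N/N=C/c1ccccc1` differs from compound 3 by hydrogen in place of chloro on an aromatic carbon. Going by the values given here, no measured step replaces a chloro with hydrogen on that aromatic carbon; the only sized step, a 5.0-fold higher number from compound 1 to compound 3 (0.70 log units; beyond the scatter), shows that the group there can shift the number by a modest amount, with the chloro giving the larger value. Taking the chloro away is therefore expected to lower the number somewhat, and the expected step of a 2.0-fold lower number from compound 3 to compound 4 (0.30 log units; within the scatter) is a modest fall that stays within the span of the measured compounds. Compound 4 is estimated at 50 ug/mL, with a likely range from 20 ug/mL to 150 ug/mL in this assay.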

Compound 4, minimum cytotoxic concentration: 100 ug/mL
For compound 4 the middle estimate is 2.0-fold (0.30 log units) below the measured one; low and high end bracket the measured number.
By their numbers in this assay, from the lowest: compound 1; then compounds 3 and 4 (each within the scatter of the next).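

In this assay, swapping the chloro for hydrogen gives no change at the digits printed from compound 3 to compound 4 (within the scatter), so the chloro itself adds nothing measurable to the number at this position. Hydrogen stands clear of the hydroxy just as the chloro does, with a 5.0-fold higher number from compound 1 to compound 4 (0.70 log units; beyond the scatter), and among these three groups at this place only the hydroxy goes with the lower number. Compound 2 gives only a limit, so its steps to the other compounds cannot be read: the limit of >= 20 ug/mL in this assay, at which 1 of the 4 values shown sits.

From the compounds shown here alone, whether the lower number is peculiar to the hydroxy remains open, as a single compound carries it. An amine or a methoxy at this same place could show whether other groups that carry oxygen or nitrogen there lower the number as well.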